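This account rests on a few compounds, and the source may have more. Where it says the series, first, only, none or still open, it means among the compounds named here.

Measured in a functional assay on PC-3 cells (Homo sapiens) for cytotoxicity, read by MTT assay, with a stated time of 72 h; a higher number here means a weaker inhibitor, a lower number a stronger inhibitor:
- compound 1 `N#Cc1ccc(/C=N/NC(=O)Nc2cc3c(Nc4ccc(F)c(Cl)c4)ncnc3cc2O[C@H]2CCOC2)cc1`: 28100 nM
- compound 2 `COc1ccc(/C=N/NC(=O)Nc2cc3c(Nc4ccc(F)c(Cl)c4)ncnc3cc2O[C@H]2CCOC2)cc1`: 34100 nM
- compound 3 `COc1cc2ncnc(Nc3ccc(F)c(Cl)c3)c2cc1NC(=O)N/N=C/c1ccc(C#N)cc1`: 36500 nM

Compound 3, at 36500 nM, sits level with the other two, since all three values lie within the usual scatter of one another.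

Compound 4 `COc1cc2ncnc(Nc3ccc(F)c(Cl)c3)c2cc1NC(=O)N/N=C/c1ccc(O)c(Br)c1` keeps the rest of compound 3 and alters one group: 3-bromo-4-hydroxyphenyl in place of 4-cyanophenyl on a carbon with a double bond to nitrogen. In words, this is 3-bromo-4-hydroxyphenyl in place of 4-cyanophenyl on a carbon with a double bond to nitrogen.

Two measured steps offer a guide. The closer one also removes the cyano group, with methoxy in place of cyano: a 1.2-fold higher number from compound 1 to compound 2 (0.08 log units; within the scatter). The other, methyl in place of oxolan-3-yl on an oxygen, gives a 1.3-fold higher number from compound 1 to compound 3 (0.11 log units; within the scatter). Neither step goes beyond the scatter. For the measured compounds named here, no measured compound carries a bromo or hydroxy group, however, so this guide is loose and the range must stay wide.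

The expected change is small, within the scatter: a 1.2-fold lower number from compound 3 to compound 4 (0.09 log units; within the scatter). Compound 4 is estimated at 30000 nM, with an expected range of 10000 nM to 70000 nM.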

Compound 4, half-maximal inhibitory concentration: 15300 nM
Compound 4: the middle estimate sits 2.0-fold (0.29 log units) above what was measured; low and high end bracket the measured number.
By their numbers in this assay, from the lowest: compounds 4, 1, 2 and 3 (each within the scatter of the next, the first and the last beyond it).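

In this assay, for the compounds shown here, 3-bromo-4-hydroxyphenyl in place of 4-cyanophenyl gives a 2.4-fold lower number from compound 3 to compound 4 (0.38 log units; beyond the scatter) and is the only step here that passes beyond the scatter. The earlier replacement of the cyano group by methoxy, seen as a 1.2-fold higher number from compound 1 to compound 2 (0.08 log units; within the scatter) on the compounds with the oxolan-3-yl group, stayed within it, so the aromatic ring on this carbon can affect the read-out, though only modestly so far. Nothing available explains why this exchange lowers the number.

Bromo and hydroxy enter together while the nitrile leaves, so the compounds shown cannot say whether bromo alone, hydroxy alone or the pair accounts for the step. Also open, on these data alone, is how an amine or a carboxylic acid on this ring would read, and whether the step would hold with oxolan-3-yl on the oxygen.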